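This account rests on a few compounds, and the source may have more. Where it says the series, first, only, none or still open, it means among the compounds named here.

In an assay on liver for inhibition of sterol O-acyltransferase 1 (Rattus norvegicus), using microsomes (on this read-out lower numbers stand for stronger inhibition and higher numbers for weaker inhibition), compound 1 `CC(C)c1cc(C(C)C)c(OS(=O)(=O)NC(=O)Oc2c(C(C)C)cccc2C(C)C)c(C(C)C)c1` gives 29000 nM, and compound 2 `CC(C)c1cccc(C(C)C)c1OS(=O)(=O)NC(=O)OC1CCCCC1` gives 38000 nM. Purely as numbers, compound 2 stands at the top of the two measured values, but its gap to compound 1 lies within the usual scatter of repeated measurements, so the two compounds cannot be told apart in this assay. Compound 3 `CC(C)c1ccccc1OC(=O)NS(=O)(=O)Oc1c(C(C)C)cccc1C(C)C` differs from compound 2 by 2-isopropylphenyl in place of cyclohexyl on an oxygen next to a carbonyl group, in words 2-isopropylphenyl in place of cyclohexyl on an oxygen next to a carbonyl group. Among the compounds with values here, no measured pair shows this change, so its effect cannot be read from the data. Compound 1 also carries an aromatic group on that oxygen and gives 29000 nM, a number close to that of compound 2. The expected step is a 1.3-fold lower number from compound 2 to compound 3 (0.10 log units; within the scatter), none beyond the scatter. Compound 3 is therefore estimated at 30000 nM, with a range from 10000 nM to 90000 nM.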

Compound 3, half-maximal inhibitory concentration: > 50000 nM
Compound 3 gave a limit, no number; the forecaster's own chance of this, stated with the estimate: 10%; middle value at least 1.6-fold (0.22 log units) from the limit.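

Within the data shown here, compound 2 and compound 3 are the only pair here that tests the change directly, with 2-isopropylphenyl in place of cyclohexyl on an oxygen next to a carbonyl group: in this assay it gives an at least 1.3-fold higher number from compound 2 to compound 3 (0.11 log units; that floor lies within the scatter). The value of compound 3, > 50000 nM, is a limit of the assay and not a number. At this position, then, the aromatic group with more heavy atoms brings no visible gain in inhibition, but the pair gives no exact size for the step, and the reading ends at a limit: the limit of > 50000 nM in this assay, at which 1 of the 3 values shown sits.

Going by these compounds, it remains open whether compound 3 truly differs from compound 2 beyond the scatter. On these data alone, it also remains open whether a longer carbon chain, an amine or a carboxylic acid on this oxygen would give a lower number.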